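Phenyl in Place of Cinnamoyl on a Weakly Active Anilide

A few compounds are considered here, and "the series" means these few. Any claim that something is new, unique, unknown or untested is made for them only; others in the source may bear on it.

Compound 1 `COc1ccc(N(CC(=O)NCCCSc2ccccc2)C(=O)/C=C/c2ccccc2)cc1` was examined in a functional assay on MCF7 cells (Homo sapiens) for cytotoxicity, read by MTT assay, with a stated time of 24 h; a higher number here means a weaker inhibitor, a lower number a stronger inhibitor. In this assay compound 1 gives >= 100000 nM, which is a limit of the assay rather than a measured number. Compound 2 `COc1ccc(N(CC(=O)NCCC[Se]c2ccccc2)C(=O)/C=C/c2ccccc2)cc1` differs from compound 1 by a selenium-containing group in place of a sulfur-containing group on a saturated chain carbon, three bonds along the chain from an amide-type nitrogen. In this assay compound 2 gives >= 100000 nM, again a limit. Going by the values given here, the step that the two limits leave unreadable from compound 1 to compound 2 therefore cannot be read, and the only evidence available is the limit of >= 100000 nM in this assay, at which 2 of the 2 values shown sit.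

Compound 3 `COc1ccc(N(CC(=O)NCCCSc2ccccc2)C(=O)c2ccccc2)cc1` has not yet been measured. It differs from compound 1 by phenyl in place of 2-phenylethenyl on a carbonyl carbon. No measured step touches the carbonyl side of the shared core, so nothing shown speaks to the size or direction of this change. With both measured values sitting at the limit, compound 3 is expected to stay close to it, and the estimated step in this assay is a number no higher from compound 1 to compound 3 (the limit leaves the size open). The estimate for compound 3 in this assay is 100000 nM, with an expected range from 30000 nM to 300000 nM.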

Compound 3, half-maximal inhibitory concentration: >= 100000 nM
Compound 3: a limit, no number (the forecaster's own chance of this, stated with the estimate: 80%); the middle value sits exactly at the limit.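

In this assay compound 3 gives >= 100000 nM as a limit of the assay, not a number. Compound 1 also sits at a limit, so the change from compound 1 to compound 3 cannot be read. The compounds shown leave open whether any change to the shared core brings a readable number in this assay at all, and the evidence so far is this: the limit of >= 100000 nM in this assay, at which 3 of the 3 values shown sit.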